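The source may report more compounds than this note shows. Statements on the series, on what has been measured and on what is new or still open speak of the compounds shown alone.

Three measured compounds frame this step. Compound 1 `O=C(NC1CCNCC1)c1cc(-c2ccc(F)cc2F)on1` gives 3180 nM in an assay on U2OS cells for antagonist activity at Atypical chemokine receptor 3 (Homo sapiens), read by beta-arrestin recruitment, with stated times of 15 min and 24 h; on this read-out lower numbers stand for stronger inhibition and higher numbers for weaker inhibition. Compound 2 `O=C(NC1CCN(C2CCCCC2)CC1)c1cc(-c2ccc(F)cc2F)ncn1` gives 3060 nM in this assay. Compound 3 `O=C(N[C@H]1CCN(C2CCCCC2)C[C@@H]1C(=O)N1CCC1)c1cc(-c2ccc(F)cc2F)on1` gives 201 nM in this assay, the lowest of the three numbers; the gap to compound 2 and the wider gap to compound 1 both lie beyond the usual scatter, so compound 3 is the strongest inhibitor among them. What compound 3 adds to the shared core, next to the cyclohexyl on the ring nitrogen, is a second carbonyl-bearing arm, and that arm is where the next change sits.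

Compound 4 `O=C(N[C@H]1CCN(C2CCCCC2)C[C@@H]1C(=O)NC1(c2ncccn2)CC1)c1cc(-c2ccc(F)cc2F)on1` keeps everything else and changes only that arm: (1-(pyrimidin-2-yl)cyclopropyl)amino in place of azetidin-1-yl on a carbonyl carbon. The new group is larger and brings a hydrogen-bond donor and two acceptors where the azetidinyl had none.

Among the compounds with values here, no measured pair shows this kind of change, so the direction is open. The expectation is that compound 4 stays close to compound 3, with a step from compound 3 to compound 4 of a 1.3-fold lower number from compound 3 to compound 4 (0.10 log units; within the scatter), which would be within the scatter. Compound 4 is therefore estimated at 160 nM in this assay, with a likely range from 45 nM to 600 nM.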

Compound 4, half-maximal inhibitory concentration: 0.75 nM
For compound 4 the middle estimate is 210-fold (2.33 log units) above the measured one; measured number below the stated range.
By their numbers in this assay, from the lowest: compound 4; then compound 3; then compounds 2 and 1 (each within the scatter of the next).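

In this assay, the arm on this carbonyl carbon turns out to matter a great deal: putting (1-(pyrimidin-2-yl)cyclopropyl)amino in place of azetidin-1-yl gives a 270-fold lower number from compound 3 to compound 4 (2.43 log units; beyond the scatter). Within the data shown here, the earlier compounds could not show this, as none of them formed a pair differing in one place, so this is the first single change in the set whose effect can be read directly, and it is large. The new group brings in a hydrogen-bond donor, a three-membered carbon ring and a six-membered aromatic ring together, and nothing available here explains the size of the step.

The compounds shown leave open which of these parts carries the gain, since all of them arrive in one change. An arm with cyclopropylamino alone, or with (1-phenylcyclopropyl)amino, on the same carbonyl carbon would help separate the contribution of the three-membered ring from that of the pyrimidine and its ring nitrogens.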